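A few compounds are considered here, and "the series" means these few. Any claim that something is new, unique, unknown or untested is made for them only; others in the source may bear on it.

In a functional assay on HeLa cells (Homo sapiens) for antiproliferative activity, read by MTT assay, with a stated time of 24 h (a higher number here means a weaker inhibitor, a lower number a stronger inhibitor), compound 1 (`COc1ccc(S(=O)(=O)n2c(-c3cn(-c4ccccc4)nc3-c3ccc(F)cc3)nc3ccccc32)cc1`) gives 390 nM and compound 2 (`COc1ccc(S(=O)(=O)n2c(-c3cn(-c4ccccc4)nc3-c3ccc(C(F)(F)F)cc3)nc3ccccc32)cc1`) gives 250 nM. Both carry the (4-methoxyphenyl)sulfonyl group. They differ elsewhere, by trifluoromethyl in place of fluoro on an aromatic carbon, and that change amounts to a 1.6-fold lower number from compound 1 to compound 2 (0.19 log units; within the scatter). Going by the values given here, compound 2 therefore stands level with compound 1, the only other measured compound, and the two numbers cannot be told apart.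

Compound 3 (`O=S(=O)(c1ccc(Br)cc1)n1c(-c2cn(-c3ccccc3)nc2-c2ccc(C(F)(F)F)cc2)nc2ccccc21`) keeps the trifluoromethyl group of compound 2 but has bromo in place of methoxy on an aromatic carbon, para to a large group, turning 4-methoxyphenyl into 4-bromophenyl: bromo in place of methoxy on an aromatic carbon. Among the compounds with values here, no measured step touches this place. Within the data shown here, the one step available concerns a different group and stayed within the scatter, so it offers no size to carry over. No step beyond the scatter is therefore expected in this assay, though the data give no direct test of this replacement. The expected step is a 1.2-fold higher number from compound 2 to compound 3 (0.08 log units; within the scatter), which would stay within the scatter. For compound 3 the estimated value is 300 nM, with an expected range from 120 nM to 750 nM.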

Compound 3, half-maximal inhibitory concentration: 1860 nM
Compound 3: middle estimate off by 6.2-fold (0.79 log units), on the low side, outside the stated range (above it).
By their numbers in this assay, from the lowest: compounds 2 and 1 (each within the scatter of the next); then compound 3.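

The aryl group on the sulfonyl, held constant between compound 1 and compound 2, proves to be the more sensitive place in this assay: with the trifluoromethyl group kept, bromo in place of methoxy gives a 7.4-fold higher number from compound 2 to compound 3 (0.87 log units; beyond the scatter) and so moves the number beyond the scatter, which the earlier change did not do. Among the compounds shown, this is the first single replacement that separates two compounds, and here the methoxy compound, compound 2, is the stronger of the pair. The data offer no measurement that would explain this step.

From the compounds shown here alone, it remains open whether the same replacement would produce a step of similar size with the fluoro group of compound 1 in place of trifluoromethyl, and whether the result reflects the arrival of bromo or the departure of methoxy. It is also open how other groups on this aromatic carbon, such as a hydroxyl, an amine or a chloro group, would read, so the compounds shown define no trend at this place beyond these two groups.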